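A few compounds are considered here, and "the series" means these few. Any claim that something is new, unique, unknown or untested is made for them only; others in the source may bear on it.

Compound 1 `COc1ccc(/C(Cl)=C/C=C(\C#N)C(=O)c2c[nH]c3ccccc23)cc1` carries the shared core together with a methoxy-bearing six-membered aromatic ring of carbon only. In a functional assay on MCF7 cells (Homo sapiens) for cytotoxicity, read by sulforhodamine B assay, with a stated time of 48 h (on this read-out lower numbers stand for stronger inhibition of growth and higher numbers for weaker inhibition of growth), compound 1 gives > 100000 nM, which is a limit of the assay and not a number. Compound 2 `N#C/C(=C\C=C(/Cl)c1ccc(Br)cc1)C(=O)c1c[nH]c2ccc(Br)cc12` is the other measured member of this small set. In this assay compound 2 gives > 100000 nM, again a limit of the assay and not a number. Within the data shown here, compound 1 thus stands at the limit of > 100000 nM in this assay, at which 2 of the 2 values shown sit, and no measured step separates it from any other compound in the set. Compound 3 `COc1ccc(/C(Cl)=C/C=C(\C#N)C(=O)c2c[nH]c3ccccc23)cc1OC` has not yet been measured. It differs from compound 1 by methoxy in place of hydrogen on an aromatic carbon. Among the measured compounds shown here, with both measured values resting on the limit, there is no measured step from which a direction could be read, and the step is expected to be none beyond the scatter, so compound 3 is expected to remain at the same limit. The change expected as a number no higher from compound 1 to compound 3 (the limit leaves the size open) is estimated to be flat. In this assay compound 3 is estimated at 100000 nM, within a range from 50000 nM to 200000 nM.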

Compound 3, concentration for total growth inhibition: > 100000 nM
Compound 3 gave a limit, no number; the forecaster's own chance of this, stated with the estimate: 85%; the middle value sits exactly at the limit.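

No step can be read from compound 1 to compound 3, methoxy in place of hydrogen on an aromatic carbon, and every compound shown rests on one value: the limit of > 100000 nM in this assay, at which 3 of the 3 values shown sit. The compounds shown leave open how strongly any of them inhibits growth in this assay, and whether this methoxy group changes that at all.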